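Shortening the ether side chain on the piperidine series

The compounds below may be only part of what the source reports. "The series", "measured", "known", "first", "only" and "open" are said of these compounds alone.

Compound 1 `NC(=O)C1CCN(Cc2ccc([C@H]3CC[C@]4(CC3)OOC3(O4)C4CC5CC(C4)CC3C5)cc2)CC1` gives 10 mL.min-1.g-1 in an ADME assay on microsomes from liver (Homo sapiens) for metabolic stability, read by LC-MS, tested at 1 uM; on this read-out lower numbers stand for slow clearance and higher numbers for fast clearance. Compound 2 `c1cc([C@H]2CC[C@]3(CC2)OOC2(O3)C3CC4CC(C3)CC2C4)ccc1OCCC1CCNCC1` gives < 7 mL.min-1.g-1 in this assay, which is a limit of the assay and not a number. This places compound 2 at the limit of < 7 mL.min-1.g-1 in this assay, at which 1 of the 2 values shown sits.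

Compound 3 `c1cc([C@H]2CC[C@]3(CC2)OOC2(O3)C3CC4CC(C3)CC2C4)ccc1OCC1CCNCC1` carries (piperidin-4-yl)methoxy where compound 2 carries 2-(piperidin-4-yl)ethoxy (piperidin-4-yl in place of (piperidin-4-yl)methyl on a saturated chain carbon bound to an oxygen on an aromatic ring).

Among the measured compounds shown here, the only measured step is an at least 1.4-fold lower number from compound 1 to compound 2 (0.15 log units; that floor lies within the scatter). For the measured compounds named here, it exchanges (4-carbamoylpiperidin-1-yl)methyl for 2-(piperidin-4-yl)ethoxy on an aromatic carbon, so it bears on the new change only indirectly, and no measured step varies the chain itself. The expected step is a step that the limit leaves unreadable from compound 2 to compound 3, which means no change beyond the scatter. For compound 3 the estimate is 6 mL.min-1.g-1, with an expected range of 3 mL.min-1.g-1 to 12 mL.min-1.g-1.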

Compound 3, intrinsic clearance in microsomes: < 7 mL.min-1.g-1
Compound 3 was reported as a limit; the forecaster's own chance of this, stated with the estimate: 55%; the middle value is on the limit's open side.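

In this assay compound 3 stands at a limit of the assay and not at a number, as compound 2 does, so the step between the two cannot be read. Set against the carbamoyl series, the read-out gives an at least 1.4-fold lower number from compound 1 to compound 3 (0.15 log units; that floor lies within the scatter) for (piperidin-4-yl)methoxy in place of (4-carbamoylpiperidin-1-yl)methyl on an aromatic carbon. Going from 2-(piperidin-4-yl)ethoxy to (piperidin-4-yl)methoxy does not lift the read-out off the limit: the limit of < 7 mL.min-1.g-1 in this assay, at which 2 of the 3 values shown sit.

As far as these compounds go, how far compound 2 and compound 3 lie under that limit stays open, and with it any order between them. Also open, from the compounds shown here alone, is whether a longer chain on the ether oxygen, or a carboxylic acid on the piperidine, would bring the read-out back to a number.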